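The source may hold more compounds than are shown below. What is called first, only, known or untested is meant among the compounds shown, and "the series" means these compounds.

Of the compounds shown here, three have so far been measured in an assay on HEK293 cells for inhibition of Voltage-dependent N-type calcium channel subunit alpha-1B (Homo sapiens), read by FLIPR and calcium flux, tested at 1 uM; on this read-out higher numbers stand for more inhibition at the one concentration tested (going by the name of the read-out) and lower numbers for less inhibition. Compound 1 `CS(=O)(=O)c1cccc(S(=O)(=O)N(C2CC2)C2CCN(C(=O)c3cc(F)ccc3S(C)(=O)=O)CC2)c1` gives 0%, compound 2 `NC(=O)c1ccccc1C(=O)N1CCC(N(C2CC2)S(=O)(=O)c2cccc(C(F)(F)F)c2)CC1` gives 15%, and compound 3 `CS(=O)(=O)c1ccc(F)cc1C(=O)N1CCC(N(C2CC2)S(=O)(=O)c2ccc(C(F)(F)F)cc2)CC1` gives 1%. Compound 3 thus stands second highest of the three numbers, within the scatter of compound 1 and beyond the scatter of compound 2. Within the data shown here, the one measured step, a number 1 percentage points higher from compound 1 to compound 3 (within the scatter), swaps the group on the sulfonyl sulfur and stays within the scatter.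

Compound 4 `CS(=O)(=O)c1ccc(F)cc1C(=O)N1CCC(N(C2CC2)S(=O)(=O)c2ccccc2C(F)(F)F)CC1` has not been measured; it differs from compound 3 by 2-(trifluoromethyl)phenyl in place of 4-(trifluoromethyl)phenyl on a sulfonyl sulfur. Among the measured compounds shown here, since the only step at this place a number 1 percentage points higher from compound 1 to compound 3 (within the scatter) hardly moved the read-out, no change beyond the scatter is expected in this assay. Compound 4 is estimated at 3%, between -6% and 14%. That estimate corresponds to an expected step of a number 2 percentage points higher from compound 3 to compound 4 (within the scatter).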

Compound 4, a percentage reported as inhibition, at one concentration (the size of the read-out at that concentration, not a potency): 17%
Estimate against measurement, compound 4: 14 percentage points below, outside the stated range (above it).
By their numbers in this assay, from the lowest: compounds 1 and 3 (each within the scatter of the next); then compounds 2 and 4 (each within the scatter of the next).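

With 2-(trifluoromethyl)phenyl in place of 4-(trifluoromethyl)phenyl on the sulfonyl sulfur, this assay shows a number 16 percentage points higher from compound 3 to compound 4 (beyond the scatter) even though the two groups hold the same atoms. Replacing 3-(methylsulfonyl)phenyl with that same group gives a number 17 percentage points higher from compound 1 to compound 4 (beyond the scatter) and so shows that a change at this place can move the read-out beyond the scatter. Nothing measured here bears on why the read-out moves.

From the compounds shown here alone, it remains open whether 2-chlorophenyl or 2-methoxyphenyl on the sulfonyl sulfur would give a similar read-out, or whether a group other than trifluoromethyl matters here.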